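An Ethyl Group Enters at the Triple Bond

A few compounds are considered here, and "the series" means these few. Any claim that something is new, unique, unknown or untested is made for them only; others in the source may bear on it.

For the measured compounds named here, only two compounds have numbers so far in an ADME assay on Vero cells (Chlorocebus sabaeus) for cytotoxicity, read by MTT assay; a lower number here means that less compound is tolerated, a higher number that more compound is tolerated. Compound 1 `C[Si](C)(C)C#Cc1c[nH]c(=O)[nH]c1=O` gives 270000 nM, and compound 2 `O=c1[nH]c(=O)n([C@@H]2O[C@H](CO)[C@@H](O)[C@H]2O)cc1C#CC1CCCCC1` gives 148000 nM. These two values lie within the usual scatter of each other, so compound 1 cannot be separated from compound 2 on these data. Going by the values given here, no measured pair differs in only one place, which leaves no direct measure of what a single change does.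

Compound 3 `CCC#Cc1c[nH]c(=O)[nH]c1=O` departs from compound 1 in one place: a group of 2 heavy atoms (2 carbon; no ring) in place of a group of 4 heavy atoms (3 carbon, 1 silicon; no ring), on a triple-bonded carbon. An ethyl group replaces the silicon-bearing group on a triple-bonded carbon, and the shared core stays the same.

No step beyond the scatter is expected in this assay. This expectation rests on compound 1 at 270000 nM and compound 2 at 148000 nM, which sit within the scatter of each other despite their different structures. The estimated step is a 1.2-fold lower number from compound 1 to compound 3 (0.09 log units; within the scatter), and it is expected to remain within the scatter. For compound 3 the estimated value is 220000 nM, with an expected range from 90000 nM to 550000 nM.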

Compound 3, half-maximal cytotoxic concentration: 263000 nM
Beside the measured number, compound 3's estimate is 1.2-fold (0.08 log units) below it; the range from low to high includes it.
By their numbers in this assay, from the lowest: compounds 2, 3 and 1 (each within the scatter of the next).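

In this assay, for the compounds shown here, this pair gives the first reading of a single change, and the step (a 1.0-fold lower number from compound 1 to compound 3 (0.01 log units; within the scatter)) shows that an ethyl group and the silicon-bearing group it replaces, on a triple-bonded carbon, cannot be told apart on the shared core. For this one pair, then, silicon and the larger group are not needed for the level of tolerated compound seen with compound 1, and the 2 heavy atoms of ethyl serve as well as the 4 heavy atoms of the group that left. No measurement is available that would explain this lack of separation.

The compounds shown span only one swap at this position, both partners being free of hydrogen-bond donors, hydrogen-bond acceptors and net charge, so they leave open how far this flat result extends. Whether a longer chain such as octyl, or a group of another kind such as an amine or a carboxylic acid, on the same triple-bonded carbon would give a step beyond the scatter in this assay remains unanswered.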